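The source may report more compounds than this note shows. Statements on the series, on what has been measured and on what is new or still open speak of the compounds shown alone.

Measured compounds in a functional assay on U-937 cells (Homo sapiens) for cytotoxicity, read by MTT assay, with a stated time of 24 h; on this read-out higher numbers stand for weaker inhibition and lower numbers for stronger inhibition:
- compound 1 `CCCCCCCCCCn1cc(-c2nc3ccccc3cc2CCC)nn1`: 26.6 ug/mL
- compound 2 `CCCCCCCCCCn1cc(-c2nc3ccccc3cc2CCCCC)nn1`: 18.2 ug/mL
- compound 3 `CCCCCc1cc2ccccc2nc1-c1cn(CCC(F)(F)C(F)(F)C(F)(F)C(F)(F)C(F)(F)C(F)(F)C(F)(F)C(F)(F)F)nn1`: > 100 ug/mL

Compound 2 gives the lower of the two numbers in this assay; the step of a 1.5-fold lower number from compound 1 to compound 2 (0.16 log units; within the scatter) leaves it and compound 1 within the scatter of each other, so no order between them is claimed. Compound 3 gives only a limit in this assay, (the limit of > 100 ug/mL in this assay, at which 1 of the 3 values shown sits), and no number.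

The step to compound 4 `CCCCCc1cc2ccccc2nc1-c1cn(-c2ccc(F)cc2)nn1` is 4-fluorophenyl in place of decyl on an aromatic nitrogen. Going by the values given here, the only measured step, a 1.5-fold lower number from compound 1 to compound 2 (0.16 log units; within the scatter), changes a saturated chain carbon on the other side of the shared core, not the substituent on the aromatic nitrogen, so it does not bear on this change and gives no size to expect from it. Among the compounds with values here, no measured pair in this assay exchanges a chain on the aromatic nitrogen for an aromatic ring, so the direction is open; a number somewhat higher than that of compound 2 is taken as the working expectation, with a wide range.

For compound 4 in this assay the estimate is 40 ug/mL, between 12 ug/mL and 100 ug/mL, an expected step of a 2.2-fold higher number from compound 2 to compound 4 (0.34 log units; beyond the scatter).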

Compound 4, half-maximal inhibitory concentration: 67.5 ug/mL
Compound 4: middle estimate off by 1.7-fold (0.23 log units), on the low side; measured number inside the range.
By their numbers in this assay, from the lowest: compounds 2 and 1 (each within the scatter of the next); then compound 4. At a limit, above all of these: compound 3.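

Going by these compounds alone, replacing decyl with 4-fluorophenyl on the aromatic nitrogen gives, in this assay, a 3.7-fold higher number from compound 2 to compound 4 (0.57 log units; beyond the scatter), the first step beyond the scatter; the chain change on the other side of the shared core, a 1.5-fold lower number from compound 1 to compound 2 (0.16 log units; within the scatter), stays within it. Compound 3, with a fluorinated chain on the same aromatic nitrogen, gives only a limit and no number: the limit of > 100 ug/mL in this assay, at which 1 of the 4 values shown sits. Nothing shown gives a reason for the step from decyl to 4-fluorophenyl.

With only one aromatic group on this nitrogen, the compounds shown do not separate the loss of decyl from the entry of the ring, and an unsubstituted phenyl, a benzyl or a shorter chain such as butyl could do so. On these data alone, whether the propyl chain of compound 1 would give a similar step with 4-fluorophenyl also remains open.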